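The source may report more compounds than this note shows. Statements on the series, on what has been measured and on what is new or still open speak of the compounds shown alone.

Three compounds share one core, and all three were measured in an assay on Cerebral cortex for displacement of a labelled ligand from adenosine receptor A1 (Bos taurus); on this read-out lower numbers stand for stronger inhibition and higher numbers for weaker inhibition. Compound 1 `CCNc1nc(-c2ccccc2)nc2c1nnn2Cc1ccccc1F` gives 11 nM. Compound 2 `Clc1ccccc1Cn1nnc2c(NC3CC3)nc(-c3ccccc3)nc21` gives 11 nM. Compound 3 `Fc1ccccc1Cn1nnc2c(NC3CC3)nc(-c3ccccc3)nc21` gives 15 nM, the highest of the three numbers, although both of its neighbours lie within the scatter of it: a 1.4-fold higher number from compound 1 to compound 3 (0.13 log units; within the scatter) and a 1.4-fold higher number from compound 2 to compound 3 (0.13 log units; within the scatter).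

The step now under consideration leads from compound 3 to compound 4 `OCCNc1nc(-c2ccccc2)nc2c1nnn2Cc1ccccc1F`. The change is 2-hydroxyethyl in place of cyclopropyl on a nitrogen on an aromatic ring. Within the data shown here, of the measured steps, only the one from compound 1 to compound 3 touches the same nitrogen, and it exchanged ethyl for cyclopropyl without leaving the scatter. No measured step introduces a hydroxyl group, so the effect of the oxygen in the 2-hydroxyethyl chain is not shown by these compounds. Given that the ethyl-for-cyclopropyl exchange was small, compound 4 is expected to stay close to compound 3, with at most a modest drift towards a higher number, an estimated 1.5-fold higher number from compound 3 to compound 4 (0.17 log units; within the scatter). The estimate for compound 4 in this assay is therefore 22 nM, with a plausible range from 7 nM to 70 nM.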

Compound 4, inhibition constant: 54 nM
The estimate for compound 4 lay 2.5-fold (0.39 log units) below the measured number; low and high end bracket the measured number.
By their numbers in this assay, from the lowest: compounds 1, 2 and 3 (each within the scatter of the next); then compound 4.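

In this assay, among these compounds, the nitrogen on the aromatic ring had so far taken ethyl and cyclopropyl without a change beyond the scatter, but 2-hydroxyethyl in place of cyclopropyl gives a 3.6-fold higher number from compound 3 to compound 4 (0.56 log units; beyond the scatter), so this position does not accept every small chain equally. Among the compounds shown here, the comparison with the ethyl chain is more specific, since the only change there is hydroxy in place of hydrogen on a saturated chain carbon, and it gives a 4.9-fold higher number from compound 1 to compound 4 (0.69 log units; beyond the scatter), which shows that the number rises beyond the scatter without any ring leaving the substituent. Nothing given here bears on why the number rises at this position.

The compounds shown leave open whether the rise belongs to the hydroxyl group itself or would also appear with a methoxyethyl chain, an aminoethyl chain or a longer hydroxyalkyl chain on the same nitrogen. They also leave open whether the 2-hydroxyethyl group would have a step of similar size with chloro in place of fluoro on the aromatic carbon.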